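From chloro to trifluoromethyl on compound 1

The source may report more compounds than this note shows. Statements on the series, on what has been measured and on what is new or still open speak of the compounds shown alone.

Measured so far in a physicochemical assay for solubility, measured as kinetic solubility (a higher number here means a more soluble compound, a lower number a less soluble compound), for three compounds:
- Compound 1 `O=C(N[C@@H](CO)c1cccc(Cl)c1)[C@H]1CC(F)(F)CC[C@@H]1c1ccccc1` gives 318000 nM
- Compound 2 `C[C@H](NC(=O)c1cc(F)c(F)cc1Oc1ccccc1)c1cccc(S(C)(=O)=O)c1` gives 145000 nM
- Compound 3 `O=C(N[C@@H](CO)c1ccccc1)[C@H]1CCCC[C@@H]1c1ccccc1` gives 455000 nM

Compound 1 lies within the scatter of compound 3 and beyond the scatter above compound 2. Compound 4 `O=C(N[C@@H](CO)c1cccc(C(F)(F)F)c1)[C@H]1CC(F)(F)CC[C@@H]1c1ccccc1` keeps the core of compound 1 but has trifluoromethyl in place of chloro on an aromatic carbon. Among the measured compounds shown here, no measured pair shows this change, so the expectation rests on compound 1 at 318000 nM and the structural difference alone. A small fall within the scatter is expected, with the estimated change a 1.3-fold lower number from compound 1 to compound 4 (0.10 log units; within the scatter) as its size. For compound 4 the expected value is 250000 nM within an estimated range of 130000 nM to 420000 nM in this measurement.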

Compound 4, solubility: 119000 nM
The estimate for compound 4 lay 2.1-fold (0.32 log units) above the measured number; measured number below the stated range.
By their numbers in this assay, from the lowest: compounds 4 and 2 (each within the scatter of the next); then compounds 1 and 3 (each within the scatter of the next).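

Trifluoromethyl in place of chloro gives a 2.7-fold lower number from compound 1 to compound 4 (0.43 log units; beyond the scatter) in this assay and is the first step here between compounds that differ in one place. It shows that, on the shared core, the read-out responds to which of these two groups sits at this position on the aromatic ring. No measurement offered here explains the step.

Still open, on these data alone, is where a nitrile or a methoxy group at this position would fall relative to chloro and trifluoromethyl. As far as these compounds go, it is also open whether the same exchange would give a step of similar size on another core.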